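The source may hold more compounds than are shown below. What is called first, only, known or untested is meant among the compounds shown, and "the series" means these compounds.

Compound 3, `O=C(/C=C/c1ccc(OCc2nc(C3CCN(Cc4ccc(F)cc4)CC3)no2)cc1)NO`, was tested in an assay on isolated protein for inhibition of protein deacetylase HDAC6 (Homo sapiens), read by fluorescence, with a stated time of 1 h, tested at 100 nM (on this read-out higher numbers stand for more inhibition at the one concentration tested (going by the name of the read-out) and lower numbers for less inhibition), where compound 3 gives 75%. That is the largest of the three numbers shown, but only within the scatter: compound 2, `Cc1ccccc1CN1CCC(c2noc(COc3ccc(/C=C/C(=O)NO)cc3)n2)CC1`, gives 68%, and compound 1, `C=CCN1CCC(c2noc(COc3ccc(/C=C/C(=O)NO)cc3)n2)CC1`, gives 66%. The steps of a number 2 percentage points higher from compound 1 to compound 2 (within the scatter), a number 9 percentage points higher from compound 1 to compound 3 (within the scatter) and a number 7 percentage points higher from compound 2 to compound 3 (within the scatter) all lie inside the scatter.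

Compound 4 is `O=C(/C=C/c1ccc(OCc2nc(C3CCN(Cc4ccccc4[N+](=O)[O-])CC3)no2)cc1)NO`. Against compound 3 the change is 2-nitrophenyl in place of 4-fluorophenyl on a saturated chain carbon bound to an amine nitrogen in a ring. Going by the values given here, every measured step so far swapped the group at this same place, and none of them moved the inhibition beyond the scatter, so no step beyond the scatter is expected here either. Compound 4 is therefore estimated to give 74%, expected to lie between 60% and 87%. The expected step is a number 1 percentage points lower from compound 3 to compound 4 (within the scatter).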

Compound 4, a percentage reported as inhibition, at one concentration (the size of the read-out at that concentration, not a potency): 63%
Compound 4: the middle estimate sits 11 percentage points above what was measured; low and high end bracket the measured number.
By their numbers in this assay, from the lowest: compounds 4, 1, 2 and 3 (each within the scatter of the next, the first and the last beyond it).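

Going by these compounds alone, the swap of 4-fluorophenyl for 2-nitrophenyl gives the first step at this position in this assay to pass the scatter, with a number 12 percentage points lower from compound 3 to compound 4 (beyond the scatter) showing that the group here can change the inhibition. This effect is limited, since a number 5 percentage points lower from compound 2 to compound 4 (within the scatter) and a number 3 percentage points lower from compound 1 to compound 4 (within the scatter) leave compound 4 level with the 2-methylphenyl and vinyl compounds. No measurement shown gives a reason for the step.

Still open, on these data alone, is whether the step follows the nitro group or where it sits, which 4-nitrophenyl and 2-fluorophenyl groups could separate. An amine on the phenyl ring also remains untested among these compounds.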